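Shortening the urea link: a new partner for compound 2

The source may hold more compounds than are shown below. What is called first, only, known or untested is meant among the compounds shown, and "the series" means these compounds.

Measured so far in an ADME assay on the whole organism (Rattus norvegicus, strain Sprague-Dawley) for pharmacokinetics, read by LC-MS, with a stated time of 24 h, at a dose of 5 mg/kg by the intravenous route; a higher number here means that more of the compound sits outside the plasma, a lower number that more of the compound stays in the plasma:
compound 1, `COc1ccc(CNC(=O)Nc2ccc(Oc3ncnc4cc(N(C)C)ccc34)cc2)cc1`: 9 L/kg
compound 2, `COc1ccc(CNC(=O)Nc2ccc(Oc3ncnc4cc(N(C)C)ccc34)cc2)cn1`: 1.4 L/kg

Among the compounds with values here, compound 2 holds the lower of the two numbers in this assay, and the only step known, a 6.4-fold lower number from compound 1 to compound 2 (0.81 log units; beyond the scatter), separates it from compound 1. Compound 3, `COc1ccc(NC(=O)Nc2ccc(Oc3ncnc4cc(N(C)C)ccc34)cc2)cc1`, has not been measured. It differs from compound 2 by 4-methoxyphenyl in place of (6-methoxypyridin-3-yl)methyl on an amide-type nitrogen. Part of this change, a carbon-only ring coming in where a ring with one nitrogen leaves, is the reverse of what the step from compound 1 to compound 2 covered, and that step was beyond the scatter. The loss of the chain carbon between ring and nitrogen is not covered by any measured step. On that basis, compound 3 is expected to move back toward compound 1 in this assay, with the size of the step uncertain; the estimate is a 3.6-fold higher number from compound 2 to compound 3 (0.55 log units; beyond the scatter). Compound 3 is therefore estimated at 5 L/kg, ranging from 1.5 L/kg to 15 L/kg.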

Compound 3, volume of distribution at steady state: 0.7 L/kg
Estimate against measurement, compound 3: 7.1-fold (0.85 log units) above, and the stated range ends above it.
By their numbers in this assay, from the lowest: compounds 3 and 2 (each within the scatter of the next); then compound 1.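

In this assay, taking the chain carbon out of 4-methoxybenzyl, so that 4-methoxyphenyl sits directly on the amide-type nitrogen, gives a 13-fold lower number from compound 1 to compound 3 (1.11 log units; beyond the scatter), so the chain carbon alone can shift this number strongly. A carbon-only ring therefore does not always go with a high number at this position, since the reading with 4-methoxyphenyl cannot be told apart from that with (6-methoxypyridin-3-yl)methyl, at a 2.0-fold lower number from compound 2 to compound 3 (0.30 log units; within the scatter). No measurement at hand explains either step.

Still open, on these data alone, is how 6-methoxypyridin-3-yl would read placed directly on the amide-type nitrogen, with no chain carbon, and so whether the two changes add up. Also open, as far as these compounds go, is how a longer chain, such as a two-carbon link to the same ring, would read in this assay.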